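Hydroxymethyl for Ethoxycarbonyl on the Pyrazole-Type Core

A few compounds are considered here, and "the series" means these few. Any claim that something is new, unique, unknown or untested is made for them only; others in the source may bear on it.

Measured compounds:
compound 1 `C/C=C/C(=O)Nc1cccc(Cn2nc(-c3ccc(Oc4ccccc4)cc3)cc2CO)c1` gives 5700 nM
compound 2 `C=CC(=O)Nc1cccc(Cn2nc(-c3ccc(Oc4ccccc4)cc3)cc2C(=O)OCC)c1` gives 7800 nM

In a functional assay on Z-138 cells (Homo sapiens) for inhibition, read by luminescence and CellTiter-Glo, with a stated time of 72 h (on this read-out higher numbers stand for weaker inhibition and lower numbers for stronger inhibition), compound 2 stands at the highest of the two numbers shown, with compound 1 at a lower value that lies within the scatter. Compound 3 `C=CC(=O)Nc1cccc(Cn2nc(-c3ccc(Oc4ccccc4)cc3)cc2CO)c1` arises from compound 2 by hydroxymethyl in place of ethoxycarbonyl on an aromatic carbon. Among the compounds with values here, no such step between measured compounds exists here, so the expectation rests on the closeness of compound 1 and compound 2 in this assay. The step from compound 2 to compound 3 is expected to be small, a 1.7-fold lower number from compound 2 to compound 3 (0.24 log units; within the scatter), if anything toward a lower number. Compound 3 is therefore estimated at 4500 nM, within 1500 nM to 13000 nM.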

Compound 3, half-maximal inhibitory concentration: 6000 nM
The estimate for compound 3 lay 1.3-fold (0.12 log units) below the measured number, within the range that was stated.
By their numbers in this assay, from the lowest: compounds 1, 3 and 2 (each within the scatter of the next).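

In this assay, hydroxymethyl in place of ethoxycarbonyl on this aromatic carbon gives a 1.3-fold lower number from compound 2 to compound 3 (0.11 log units; within the scatter), so the two groups cannot be told apart at this position on this read-out. On the carbonyl carbon, vinyl in place of prop-1-en-1-yl gives a 1.1-fold higher number from compound 1 to compound 3 (0.02 log units; within the scatter), so neither change separates the compounds. Nothing shown gives a reason for either step. Going by these compounds, whether a carboxylic acid or an amine on this aromatic carbon, or a longer chain ending in hydroxyl, would move the number beyond the scatter remains open.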